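The source may hold more compounds than are shown below. What is called first, only, known or untested is meant among the compounds shown, and "the series" means these compounds.

Measured so far:
compound 1 `CC1C(=O)c2nc(CCCN3N=C(Cl)CCC3=O)[nH]c2N(C)C1=O` — 8800 nM
compound 2 `CC1C(=O)c2nc(CCCN3N=CCCC3=O)[nH]c2N(C)C1=O` — 12700 nM

Both numbers come from an assay on isolated protein for binding affinity to adenosine receptor A1 (Homo sapiens); on this read-out higher numbers stand for weaker inhibition and lower numbers for stronger inhibition. Compound 1 stands at the lower of the two only nominally: the step of a 1.4-fold higher number from compound 1 to compound 2 (0.16 log units; within the scatter) lies within the scatter, so the two cannot be ordered. The change in that step is hydrogen in place of chloro on a carbon with a double bond to nitrogen.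

Compound 3 `CCCC1C(=O)c2nc(CCCN3N=C(Cl)CCC3=O)[nH]c2N(C)C1=O` is not yet measured. It differs from compound 1 by ethyl in place of hydrogen on a saturated chain carbon bound to a saturated ring carbon; cut one bond further out, the same difference reads methyl to propyl. Going by the values given here, no measured step touches this part of the shared core, and the single recorded step, concerning chloro versus hydrogen, is itself within the scatter, so nothing known points to a shift in either direction. For compound 3 the estimated step is a 1.1-fold lower number from compound 1 to compound 3 (0.04 log units; within the scatter), with no change beyond the scatter expected but wide uncertainty. The estimate for compound 3 is 8000 nM, expected range 2500 nM to 26000 nM.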

Compound 3, inhibition constant: 1200 nM
Estimate against measurement, compound 3: 6.7-fold (0.82 log units) above, and the stated range ends above it.
By their numbers in this assay, from the lowest: compound 3; then compounds 1 and 2 (each within the scatter of the next).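

In this assay this saturated chain carbon bound to a saturated ring carbon responds to substitution: ethyl in place of hydrogen, read one bond further out as methyl to propyl, gives a 7.3-fold lower number from compound 1 to compound 3 (0.87 log units; beyond the scatter) and so moves the number beyond the scatter. Going by these compounds alone, the only earlier step, a 1.4-fold higher number from compound 1 to compound 2 (0.16 log units; within the scatter) on the carbon with a double bond to nitrogen, stayed within the scatter and gave no sign of how this other position would behave. No available evidence bears on the reason for the size of this step.

Going by these compounds, whether a butyl or longer chain, a branched chain such as isopropyl, or a chain ending in an amine or a carboxylic acid would extend, keep or reverse this step remains open. Also open, on these data alone, is whether methyl to propyl gives a similar step on compound 2, which carries hydrogen in place of chloro.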